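Dropping a Methyl Group: Expected Cytotoxicity of Compound 3

The source may hold more compounds than are shown below. What is called first, only, known or untested is meant among the compounds shown, and "the series" means these compounds.

Compound 1 `Cc1cnc(C(=O)NN2C(=O)CS[C@@H]2c2ccc([N+](=O)[O-])cc2)cn1` gives > 100 ug/mL in an ADME assay on PANC-1 cells (Homo sapiens) for cytotoxicity, read by MTT assay, with a stated time of 5 days; on this read-out higher numbers stand for weaker inhibition and lower numbers for stronger inhibition.
Compound 2 `Cc1cnc(C(=O)NN2C(=O)CS[C@H]2c2ccc(N(C)C)cc2)cn1` gives > 100 ug/mL in this assay.

Each of these values is a limit of the assay, not a measured number. Compound 1 thus stands only at the limit, as summarised by the limit of > 100 ug/mL in this assay, at which 2 of the 2 values shown sit. Compound 3 `O=C(NN1C(=O)CS[C@@H]1c1ccc([N+](=O)[O-])cc1)c1cnccn1` differs from compound 1 by hydrogen in place of methyl on an aromatic carbon. Within the data shown here, no measured step of this kind exists here. The step that the limit leaves unreadable from compound 1 to compound 3 is expected to be none beyond the scatter. Compound 3 is estimated at 150 ug/mL, between 60 ug/mL and 400 ug/mL, most likely reported again only as a limit.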

Compound 3, half-maximal inhibitory concentration: > 100 ug/mL
Compound 3: only a limit was reported; the forecaster's own chance of this, stated with the estimate: 85%; the middle value does not contradict the limit.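

Compound 1 and compound 3 each give only a limit of the assay, not a number, so no step between them can be read: the limit of > 100 ug/mL in this assay, at which 3 of the 3 values shown sit.

The compounds shown leave open how strongly any of them acts in this assay, and whether hydrogen in place of methyl changes that at all.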